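The compounds below may be only part of what the source reports. "The series", "measured", "known", "first", "only" and "open" are said of these compounds alone.

Compound 1 `CSCC(=O)N1CCN(c2nc(=O)c3cc(C(F)(F)F)cc([N+](=O)[O-])c3s2)CC1` gives 15.2 ug/mL in a physicochemical assay for solubility, read by HPLC (a higher number here means a more soluble compound, a lower number a less soluble compound), and stands as the higher of the two numbers recorded so far; its nearest neighbour is compound 2 `O=C(c1cccc(F)c1)N1CCN(c2nc(=O)c3cc(C(F)(F)F)cc([N+](=O)[O-])c3s2)CC1`, which in this assay gives 0.2 ug/mL. Within the data shown here, the one measured step, a 76-fold lower number from compound 1 to compound 2 (1.88 log units; beyond the scatter), puts 3-fluorophenyl in place of (methylsulfanyl)methyl on a carbonyl carbon.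

Compound 3 `O=C(c1ccc(F)cc1)N1CCN(c2nc(=O)c3cc(C(F)(F)F)cc([N+](=O)[O-])c3s2)CC1` has not yet been measured in this assay. Its difference from compound 1 is as follows: 4-fluorophenyl in place of (methylsulfanyl)methyl on a carbonyl carbon. The step from compound 1 to compound 2 is the only one that bears on this change: the same group leaves, the place is the same carbonyl carbon, and the entering group is again a fluorophenyl, 4-fluorophenyl here rather than 3-fluorophenyl. That step, a 76-fold lower number from compound 1 to compound 2 (1.88 log units; beyond the scatter), was large and beyond the scatter, so a downward step of comparable size is expected in this assay for compound 3. The estimate for compound 3 is 0.3 ug/mL, with a range from 0.08 ug/mL to 1.2 ug/mL. This corresponds to an expected step of a 51-fold lower number from compound 1 to compound 3 (1.70 log units; beyond the scatter).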

Compound 3, solubility: 1.69 ug/mL
Compound 3: middle estimate off by 5.6-fold (0.75 log units), on the low side, outside the stated range (above it).
By their numbers in this assay, from the lowest: compound 2; then compound 3; then compound 1.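

Working from this assay, the place of the fluorine on the phenyl ring carries weight on its own at this carbonyl carbon: 4-fluorophenyl in place of 3-fluorophenyl gives an 8.5-fold higher number from compound 2 to compound 3 (0.93 log units; beyond the scatter), so the two fluorophenyl groups cannot be treated as interchangeable here. Loss of (methylsulfanyl)methyl still lowers the number, but the size of that drop depends on which group enters, with a 9.0-fold lower number from compound 1 to compound 3 (0.95 log units; beyond the scatter) for 4-fluorophenyl set against a 76-fold lower number from compound 1 to compound 2 (1.88 log units; beyond the scatter) for 3-fluorophenyl, and compound 1 stays the highest of the three. No measured data on these compounds account for the gap between the two fluorophenyl isomers.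

On these data alone, whether a phenyl ring without fluorine, or a chain ending in an amine or a carboxylic acid, would fall nearer compound 1 or compound 2 on this carbonyl carbon remains open. As far as these compounds go, the three compounds also share a single core, so it remains open whether the gap between the two fluorophenyl groups would hold on any other core.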